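Benzyloxy in place of dichlorobenzyloxy: expected inactivity

The source may report more compounds than this note shows. Statements on the series, on what has been measured and on what is new or still open speak of the compounds shown alone.

In a functional assay on ECa-109 cells (Homo sapiens) for cytotoxicity, read by MTT assay, with a stated time of 72 h (a lower number here means a stronger inhibitor, a higher number a weaker inhibitor), compound 1 `COc1ccc(NC(=O)COC(=O)/C=C/c2cc(OC)c(OCc3ccc(Cl)c(Cl)c3)c(OC)c2)cc1` returns only the limit of the assay, > 200000 nM. Compound 2 `CCOc1ccc(COc2c(OC)cc(/C=C/C(=O)OCC(=O)Nc3ccccc3)cc2OC)cc1` likewise returns only a limit in this assay, > 200000 nM. Compound 1 therefore stands at the limit of > 200000 nM in this assay, at which 2 of the 2 values shown sit; no measured step separates it from another compound, and the two shown values give no order between compound 1 and compound 2. Compound 3 `COc1ccc(NC(=O)COC(=O)/C=C/c2cc(OC)c(OCc3ccccc3)c(OC)c2)cc1` differs from compound 1 by phenyl in place of 3,4-dichlorophenyl on a saturated chain carbon bound to an oxygen on an aromatic ring. Because both shown values sit at the limit of > 200000 nM in this assay, at which 2 of the 2 values shown sit, compound 3 is expected to stay at or near the limit as well, so the estimated step that the limit leaves unreadable from compound 1 to compound 3 in this assay is expected to be none beyond the scatter. Compound 3 is estimated at about 250000 nM in this assay, within 80000 nM to 800000 nM, and most probably it is again reported only as a limit.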

Compound 3, half-maximal inhibitory concentration: > 200000 nM
Compound 3 gave a limit, no number (the forecaster's own chance of this, stated with the estimate: 85%); the middle value does not contradict the limit.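

In this assay compound 3 gives > 200000 nM, a limit and not a number. No step from compound 1 to compound 3 can be read: the limit of > 200000 nM in this assay, at which 3 of the 3 values shown sit.

The compounds shown leave open whether any change on the shared core gives a measurable value in this assay.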